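The source may report more compounds than this note shows. Statements on the series, on what has been measured and on what is new or still open speak of the compounds shown alone.

Measured so far:
- compound 1 `COc1cccc2oc(/C=C/[S+](C)[O-])cc(=O)c12`: 3800 nM
- compound 2 `CCCCOc1ccc2oc(/C=C/[S+](C)[O-])cc(=O)c2c1`: 1400 nM

In a functional assay on A549 cells (Homo sapiens) for cytotoxicity, with a stated time of 48 h (a lower number here means a stronger inhibitor, a higher number a weaker inhibitor), compound 2 stands lowest of the two numbers; compound 1 gives the higher number, and the gap between them lies beyond the scatter. Going by the values given here, no single-point step connects these two, so the pair shows only that much.

Compound 3 `CC(C)Oc1ccc2oc(/C=C/[S+](C)[O-])cc(=O)c2c1` is not yet measured. It differs from compound 2 by isopropyl in place of butyl on an oxygen on an aromatic ring.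

Among the compounds with values here, no measured step covers this kind of change, so the size can only be guessed. A small step toward a higher number is expected, a 1.4-fold higher number from compound 2 to compound 3 (0.15 log units; within the scatter), about at the edge of the scatter. Compound 3 is estimated at 2000 nM, with a range from 900 nM to 4500 nM.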

Compound 3, half-maximal inhibitory concentration: 1500 nM
The estimate for compound 3 lay 1.3-fold (0.12 log units) above the measured number; measured number inside the range.
By their numbers in this assay, from the lowest: compounds 2 and 3 (each within the scatter of the next); then compound 1.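

In this assay, replacing butyl with isopropyl on this oxygen gives a 1.1-fold higher number from compound 2 to compound 3 (0.03 log units; within the scatter), so compound 2 and compound 3 cannot be told apart. Going by these compounds alone, this is the first single-point step, and it shows that at this position a branched isopropyl and a straight butyl read alike, despite the difference in heavy atoms. Nothing available accounts for this match. As far as these compounds go, whether a longer chain such as octyl would read the same remains open. So does the effect of an amine or a carboxylic acid at the end of the chain on this oxygen.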